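The source may report more compounds than this note shows. Statements on the series, on what has been measured and on what is new or still open speak of the compounds shown alone.

Compound 1 `Cc1cc(NC(=O)Nc2ccccc2F)c2ccccc2n1` gives 817 10^-6 cm/s in an ADME assay for permeability, using PAMPA, at pH 7.4; on this read-out lower numbers stand for lower permeability and higher numbers for higher permeability.
Compound 2 `Cc1cc(NC(=O)Nc2cccc(Cl)c2)c2ccccc2n1` gives 566 10^-6 cm/s in this assay.
Compound 3 `CSc1ccccc1NC(=O)Nc1cc(C)nc2ccccc12` gives 1260 10^-6 cm/s in this assay.

All three compounds share one core and differ only in the ring on the far side of the urea linker. Compound 1 sits close to both of its neighbours: the step of a 1.4-fold lower number from compound 1 to compound 2 (0.16 log units; within the scatter) and the step of a 1.5-fold higher number from compound 1 to compound 3 (0.19 log units; within the scatter) are each too small to count as a real difference, so the three numbers form a tight cluster rather than a ranking.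

Compound 4 `Cc1cc(NC(=O)Nc2ccc(F)cc2F)c2ccccc2n1` is the next compound to be measured. It differs from compound 1 in a single place: fluoro in place of hydrogen on an aromatic carbon.

For the measured compounds named here, no measured pair shows exactly this change. The two steps that come closest both alter the same phenyl ring of compound 1, and both stayed within the scatter: a 1.4-fold lower number from compound 1 to compound 2 (0.16 log units; within the scatter) and a 1.5-fold higher number from compound 1 to compound 3 (0.19 log units; within the scatter). On that basis the expectation for the step of a 1.0-fold higher number from compound 1 to compound 4 (0.02 log units; within the scatter) in this assay is no change beyond the scatter, in either direction.

Compound 4 is therefore estimated at 850 10^-6 cm/s in this assay, with a range from 500 10^-6 cm/s to 1400 10^-6 cm/s.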

Compound 4, apparent permeability: 640 10^-6 cm/s
Beside the measured number, compound 4's estimate is 1.3-fold (0.12 log units) above it; the range from low to high includes it.
By their numbers in this assay, from the lowest: compounds 2, 4, 1 and 3 (each within the scatter of the next, the first and the last beyond it).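

Compounds 2 and 3 swapped one group on the phenyl ring or moved it elsewhere on that ring, whereas compound 4 keeps the fluoro of compound 1 and adds a second one on a previously open aromatic carbon, meta to that fluoro and para to a large group. In this assay this addition gives a 1.3-fold lower number from compound 1 to compound 4 (0.11 log units; within the scatter), so at this position, with this small group and on this ring, the read-out shows no difference beyond the usual scatter of repeated measurements. Nothing measured here explains this result or says what the added fluoro does to the molecule.

A single change at a single position cannot show whether the result depends on the fluoro already on the ring, so the same position in a ring without that first fluoro remains an open case. Going by these compounds, it is also open whether a chloro, a methoxy group, an amine or a carboxylic acid at this position would stay within the scatter of compound 1 or shift the read-out beyond it.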